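Removing a methyl from the aromatic oxygen of compound 3

A few compounds are considered here, and "the series" means these few. Any claim that something is new, unique, unknown or untested is made for them only; others in the source may bear on it.

The series shares one core, first seen in compound 1 `O=C(N/N=C/c1ccccc1)c1cnccn1`, which in an ADME assay on J774 cells (Mus musculus) for cytotoxicity, read by MTT assay, with a stated time of 48 h, tested at 50 ug/mL (on this read-out lower numbers stand for a stronger effect and higher numbers for a weaker effect at the one concentration tested), gives 100%. Compound 2 `O=C(N/N=C/c1ccccc1Cl)c1cnccn1` gives 70%, and compound 3 `COc1ccccc1/C=N/NC(=O)c1cnccn1` gives 97%. Among these three numbers compound 3 stands second highest: it sits within the scatter of compound 1, as the step of a number 3 percentage points lower from compound 1 to compound 3 (within the scatter) shows, and clearly above compound 2, as the step of a number 27 percentage points higher from compound 2 to compound 3 (beyond the scatter) shows. The step of a number 30 percentage points lower from compound 1 to compound 2 (beyond the scatter) is the only one so far that moves the read-out beyond the scatter.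

Compound 4 `O=C(N/N=C/c1ccccc1O)c1cnccn1` differs from compound 3 by one change: hydrogen in place of methyl on an oxygen on an aromatic ring. Going by the values given here, no measured compound carries a hydroxy, so the steps that bear on this change are only indirect. The step of a number 3 percentage points lower from compound 1 to compound 3 (within the scatter) shows that adding a methoxy at this place changed nothing beyond the scatter, while the step of a number 27 percentage points higher from compound 2 to compound 3 (beyond the scatter) shows that a methoxy in place of chloro moved the number modestly. Since a single carbon leaves and nothing with a ring or a charge enters, the step of a number 4 percentage points lower from compound 3 to compound 4 (within the scatter) is expected to stay within the scatter. Compound 4 is therefore estimated at 93%, with a range of 78% to 100%.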

Compound 4, a percentage reported as activity, at one concentration (the size of the read-out at that concentration, not a potency): 1%
For compound 4 the middle estimate is 92 percentage points above the measured one; the whole stated range lies above it.
By their numbers in this assay, from the lowest: compound 4; then compound 2; then compounds 3 and 1 (each within the scatter of the next).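

In this assay, the loss of a single methyl from the aromatic oxygen appears as a number 96 percentage points lower from compound 3 to compound 4 (beyond the scatter), so an oxygen at this place is not enough for the strong effect: compound 3 carries one and stays within the scatter of compound 1, whereas the hydroxy of compound 4 does not. The earlier compounds had suggested a position where substitution changes the number little or modestly, yet hydroxy in place of hydrogen gives a number 99 percentage points lower from compound 1 to compound 4 (beyond the scatter), and hydroxy in place of chloro gives a number 69 percentage points lower from compound 2 to compound 4 (beyond the scatter), which leaves compound 4 with the strongest effect of the four and makes this position far more sensitive to the nature of the group than chloro or methoxy had shown. Nothing available explains why this one change has so large an effect.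

The compounds shown leave open whether the effect is particular to hydroxy or would also appear with an amine or a carboxylic acid on the same aromatic carbon. They also leave open how an ethoxy would behave there, and, with only one concentration tested, how the effect of compound 4 would change at other concentrations.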